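Removing the Aminopiperidine from a Sodium/Hydrogen Exchanger Inhibitor

The source may report more compounds than this note shows. Statements on the series, on what has been measured and on what is new or still open speak of the compounds shown alone.

Compound 1 `Cc1cc(F)c(S(C)(=O)=O)cc1C(=O)N=C(N)N`: 44 nM
Compound 2 `Cc1cc(N2CCC(N)CC2)c(S(C)(=O)=O)cc1C(=O)N=C(N)N`: 9.8 nM

For the measured compounds named here, in a functional assay for inhibition of sodium/hydrogen exchanger (Oryctolagus cuniculus) (on this read-out higher numbers stand for weaker inhibition and lower numbers for stronger inhibition), compound 2 holds the lowest of the two numbers, and the single measured step is a 4.5-fold lower number from compound 1 to compound 2 (0.65 log units; beyond the scatter). Compound 3 `Cc1ccc(S(C)(=O)=O)cc1C(=O)N=C(N)N` differs from compound 2 in one place: hydrogen in place of 4-aminopiperidin-1-yl on an aromatic carbon. That step at the same aromatic carbon is the only one that bears on this change, and it was modest. A rise of similar size is expected for compound 3 because compound 1 with fluoro at that carbon gives 44 nM, so the expected step is a 4.1-fold higher number from compound 2 to compound 3 (0.61 log units; beyond the scatter). Compound 3 is estimated at 40 nM, with a range of 15 nM to 120 nM.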

Compound 3, half-maximal inhibitory concentration: 150 nM
Beside the measured number, compound 3's estimate is 3.8-fold (0.57 log units) below it; measured number above the stated range.
By their numbers in this assay, from the lowest: compound 2; then compound 1; then compound 3.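

In this assay, hydrogen proves the poorest of the three groups at this aromatic carbon: removing 4-aminopiperidin-1-yl gives a 15-fold higher number from compound 2 to compound 3 (1.18 log units; beyond the scatter) and removing fluoro gives a 3.4-fold higher number from compound 1 to compound 3 (0.53 log units; beyond the scatter). Fluoro is therefore no neutral starting point, since it already lowers the number relative to hydrogen, and the full contribution of 4-aminopiperidin-1-yl is larger than its step from fluoro suggested.

A plain piperidin-1-yl group or a short chain ending in an amine could show whether the ring, the amine or both matter here. No measurement in hand explains why these three groups differ.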